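From a Bromophenyl Group to 1-Carboxyethyl

This account rests on a few compounds, and the source may have more. Where it says the series, first, only, none or still open, it means among the compounds named here.

Of the compounds shown here, three sharing one core have been read so far in a functional assay on K562 cells (Homo sapiens) for cytotoxicity, read by trypan blue exclusion, with a stated time of 96 h (on this read-out lower numbers stand for stronger inhibition and higher numbers for weaker inhibition), with differing results. Compound 1 (`COC(=O)C(F)(F)Nc1cc(CS(=O)(=O)/C=C/c2c(OC)cc(OC)cc2OC)ccc1OC`) gives 250 nM there, compound 2 (`COC(=O)C(Nc1cc(CS(=O)(=O)/C=C/c2c(OC)cc(OC)cc2OC)ccc1OC)c1ccccc1`) gives 30 nM and compound 3 (`COC(=O)C(Nc1cc(CS(=O)(=O)/C=C/c2c(OC)cc(OC)cc2OC)ccc1OC)c1ccc(Br)cc1`) gives 200 nM on the same scale. Compound 3 stands level with compound 1 (a 1.3-fold lower number from compound 1 to compound 3 (0.10 log units; within the scatter)) and clearly above compound 2, whose number is the lowest of the three. Compound 4 (`COc1cc(OC)c(/C=C/S(=O)(=O)Cc2ccc(OC)c(N[C@@H](C)C(=O)O)c2)c(OC)c1`) has not yet been measured. It carries 1-carboxyethyl in place of (4-bromophenyl)(methoxycarbonyl)methyl on a nitrogen on an aromatic ring. The closest guide is the bromo in place of hydrogen on an aromatic carbon (a 6.7-fold higher number from compound 2 to compound 3 (0.82 log units; beyond the scatter)), and compound 4 has no bromo. Earlier changes on the same nitrogen gave a modest step in one case (an 8.3-fold lower number from compound 1 to compound 2 (0.92 log units; beyond the scatter)) and none beyond the scatter in another (a 1.3-fold lower number from compound 1 to compound 3 (0.10 log units; within the scatter)). Among the compounds with values here, no measured compound carries 1-carboxyethyl, so the comparison is loose. A modest step toward a lower number in this assay is therefore expected. The expected step is estimated as follows (a 2.5-fold lower number from compound 3 to compound 4 (0.40 log units; beyond the scatter)). Compound 4 is estimated at 80 nM with 15 nM to 450 nM as its expected range.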

Compound 4, half-maximal inhibitory concentration: 15 nM
Compound 4: middle estimate off by 5.3-fold (0.73 log units), on the high side; the measured number falls inside the stated range.
By their numbers in this assay, from the lowest: compounds 4 and 2 (each within the scatter of the next); then compounds 3 and 1 (each within the scatter of the next).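

In this assay the exchange on this nitrogen gives a 13-fold lower number from compound 3 to compound 4 (1.12 log units; beyond the scatter) as a large step, and the same group gives a 17-fold lower number from compound 1 to compound 4 (1.22 log units; beyond the scatter) as a second large step. Against the remaining compound, a 2.0-fold lower number from compound 2 to compound 4 (0.30 log units; within the scatter) stays within the scatter, so compound 4 stands level with compound 2 and shows that a group with no ring on this nitrogen can match the best number seen so far. The data shown offer no explanation for these steps.

Compound 4 differs from compound 3 at several points at once, so the carboxylic acid, the methyl on its stereocentre and the loss of the bromophenyl ring cannot be separated. On these data alone, the methyl ester of 1-carboxyethyl, the opposite stereoisomer, an amide and a longer chain carrying the carboxylic acid remain open questions.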